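Swapping cyclopropyl for a methylpyridine on the shared core

A few compounds are considered here, and "the series" means these few. Any claim that something is new, unique, unknown or untested is made for them only; others in the source may bear on it.

Compound 1 `CN(Cc1ccc2nccn2c1)c1nnc(-c2ccc(C3CC3)cc2)o1` sits at the weak end of the three measured compounds: in an assay on isolated protein for inhibition of tyrosine-protein kinase Mer (Homo sapiens), read by LC-MS (a higher number here means a weaker inhibitor, a lower number a stronger inhibitor), compound 1 gives 794 nM, the highest number of the set. Compound 2 `CN(Cc1ccc2nccn2c1)c1nnc(-c2ccc(-c3ccccc3)cc2)o1` gives 39.8 nM and compound 3 `CN(Cc1ccc2nccn2c1)c1nnc(-c2ccc(-c3ccccc3C#N)cc2)o1` gives 25.1 nM. The change to compound 4 `Cc1ncccc1-c1ccc(-c2nnc(N(C)Cc3ccc4nccn4c3)o2)cc1` is 2-methylpyridin-3-yl in place of cyclopropyl on an aromatic carbon. Within the data shown here, two measured steps bear directly on it, since both replace the same cyclopropyl with an aromatic ring: a 20-fold lower number from compound 1 to compound 2 (1.30 log units; beyond the scatter) and a 32-fold lower number from compound 1 to compound 3 (1.50 log units; beyond the scatter). The further step a 1.6-fold lower number from compound 2 to compound 3 (0.20 log units; within the scatter) shows that adding a small group to that ring shifts the number only within the scatter. A large drop is therefore expected for compound 4, about a 20-fold lower number from compound 1 to compound 4 (1.30 log units; beyond the scatter). Compound 4 is estimated at 40 nM, within a range of 12 nM to 130 nM.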

Compound 4, half-maximal inhibitory concentration: 50.1 nM
Compound 4: middle estimate off by 1.3-fold (0.10 log units), on the low side, within the range that was stated.
By their numbers in this assay, from the lowest: compounds 3, 2 and 4 (each within the scatter of the next); then compound 1.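

The gain over cyclopropyl survives when the incoming ring carries a ring nitrogen and a methyl group, with a 16-fold lower number from compound 1 to compound 4 (1.20 log units; beyond the scatter) as the step. Compared with the other two aromatic groups, 2-methylpyridin-3-yl shows a 1.3-fold higher number from compound 2 to compound 4 (0.10 log units; within the scatter) and a 2.0-fold higher number from compound 3 to compound 4 (0.30 log units; within the scatter) as steps, so phenyl, 2-cyanophenyl and 2-methylpyridin-3-yl cannot be told apart at this position. No measurement here explains why these aromatic groups outperform cyclopropyl. Still open, going by these compounds, is how an amine or a carboxylic acid on that ring, or a longer chain in its place, would read.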